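Chloro for Bromo on the Benzoyl Ring

A few compounds are considered here, and "the series" means these few. Any claim that something is new, unique, unknown or untested is made for them only; others in the source may bear on it.

Of the compounds shown here, two built on a shared core have been tested in a functional assay on MCF7 cells (Homo sapiens) for inhibition, read by sulforhodamine B assay, with a stated time of 48 h, tested at 10 uM; a lower number here means less inhibition of growth, a higher number more inhibition of growth at the concentration tested. Compound 1 `CC(=O)c1cccc(Nc2ccnc(SCC(=O)c3ccc(C(F)(F)F)cc3)n2)c1` gives 26% in this assay. Compound 2 `CC(=O)c1ccc(Nc2ccnc(SCC(=O)c3ccc(Br)cc3)n2)cc1` gives 18% in this assay, the smaller of the two numbers as they stand, though compound 1 lies within the scatter of it, so the pair cannot truly be told apart. Compound 3 `CC(=O)c1ccc(Nc2ccnc(SCC(=O)c3ccc(Cl)cc3)n2)cc1` is not yet measured. It differs from compound 2 in one place: chloro in place of bromo on an aromatic carbon. Going by the values given here, no step between measured compounds is available to show what this exchange does in this assay. The exchange is expected to bring no change beyond the scatter, so the step of no change at the digits printed from compound 2 to compound 3 (within the scatter) is expected to be small in this assay. Compound 3 is therefore expected to give about 18% in this assay, with a range from 8% to 30%.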

Compound 3, percent growth inhibition at one concentration: 19%
For compound 3 the middle estimate is 1 percentage points below the measured one, and the stated range covers the measured number.
By their numbers in this assay, from the lowest: compounds 2, 3 and 1 (each within the scatter of the next).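

The step from 4-bromophenyl to 4-chlorophenyl gives a direct reading of this exchange in this assay: a number 1 percentage points higher from compound 2 to compound 3 (within the scatter). Going by these compounds alone, at this place on the aromatic ring, para to a large group, chloro and bromo therefore cannot be told apart at the single concentration tested, which the earlier compounds, differing from each other in more than one place, could not show. Nothing at hand speaks to the reason for this result.

Going by these compounds, what an amine or a carboxylic acid on that same carbon would do remains open, since the two halogens span only a narrow part of what could stand there. Compound 1 also differs from compound 2 and compound 3 in more than one place, so the effect of its trifluoromethyl group at this position cannot be read from these compounds.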